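Will a shorter chain change compound 3?

This account rests on a few compounds, and the source may have more. Where it says the series, first, only, none or still open, it means among the compounds named here.

In an ADME assay on HEK293 cells (Homo sapiens) for inhibition, read by MTT assay, with stated times of 18 h and 4 h (a lower number here means a stronger inhibitor, a higher number a weaker inhibitor), compound 1 `CCCCCCCCCCCCCCCCOP(=O)(O)OCCSC(=S)N1CCCCCC1` gives > 100000 nM as a limit of the assay and not a number. Compound 2 `CCCOP(=O)(O)OCCSC(=S)N1CCCCC1` gives > 100000 nM which is also a limit. Compound 3 `CCCCCCCCCCCCCCCCOP(=O)(O)OCCSC(=S)N1CCN(C)CC1` gives > 100000 nM and this too is only a limit. The evidence so far is thus the limit of > 100000 nM in this assay, at which 3 of the 3 values shown sit, and nothing sharper. Compound 4 `CCCCCCCCOP(=O)(O)OCCSC(=S)N1CCN(C)CC1` has a shorter chain than compound 3 through hydrogen in place of octyl on a saturated chain carbon, eight bonds along the chain from an oxygen on an unsaturated carbon with nothing else altered. For the measured compounds named here, the only measured step nearby is a step that the two limits leave unreadable from compound 1 to compound 3 and it changes another part of the molecule, so it offers no size to carry over. The estimated a number no higher from compound 3 to compound 4 (the limit leaves the size open) is no shift beyond the scatter in this assay and another limit is likely. Compound 4 is expected at about 100000 nM with an estimated range of 40000 nM to 250000 nM if a number is reported at all.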

Compound 4, half-maximal inhibitory concentration: 86000 nM
Compound 4: the middle estimate sits 1.2-fold (0.07 log units) above what was measured, and the stated range covers the measured number.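

In this assay, shortening the chain, with hydrogen in place of octyl on a saturated chain carbon, gives an at least 1.1-fold lower number from compound 3 to compound 4 (0.06 log units; that floor lies within the scatter). Compound 4 is the first compound shown with a measured number and not a limit, but the true size of this step stays open, and so far it shows no change beyond the scatter. The other compounds give no number to compare with: the limit of > 100000 nM in this assay, at which 3 of the 4 values shown sit.

Still open, from the compounds shown here alone, is whether a butyl chain on the same core would give a lower number, and whether the octyl chain would read the same with a morpholine ring in place of the 4-methylpiperazin-1-yl group.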